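Pyrazolyl-thiazolidinone-triazole series: aryloxymethyl and halogen changes

The source may hold more compounds than are shown below. What is called first, only, known or untested is meant among the compounds shown, and "the series" means these compounds.

Measured so far:
compound 1 `Cc1ccccc1OCc1nnc(S)n1N1C(=O)CSC1c1c[nH]nc1-c1ccc(Cl)cc1` gives 22 ug/mL
compound 2 `O=C1CSC(c2c[nH]nc2-c2ccc(Cl)cc2)N1n1c(S)nnc1COc1ccc2ccccc2c1` gives 100 ug/mL
compound 3 `O=C1CSC(c2c[nH]nc2-c2ccc(F)cc2)N1n1c(S)nnc1COc1ccc2ccccc2c1` gives > 100 ug/mL

All values come from a functional assay on MCF7 cells (Homo sapiens) for inhibition, read by MTT assay, with a stated time of 24 h; on this read-out lower numbers stand for stronger inhibition and higher numbers for weaker inhibition. Compound 3 gives only a limit of this assay, (the limit of > 100 ug/mL in this assay, at which 1 of the 3 values shown sits), and no number.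

Two single-point changes are shown. From compound 2 to compound 1 the change is 2-methylphenyl in place of naphthalen-2-yl on an oxygen on a saturated carbon, and it gives a 4.5-fold lower number from compound 2 to compound 1 (0.66 log units; beyond the scatter). From the compounds shown here alone, from compound 2 to compound 3 the change is fluoro in place of chloro on an aromatic carbon, and it gives a number no lower from compound 2 to compound 3 (the limit leaves the size open); with the limit on compound 3 the size of that step stays open.

Compound 4 `Cc1ccccc1OCc1nnc(S)n1N1C(=O)CSC1c1c[nH]nc1-c1ccc(F)cc1` is not yet measured in this assay. It differs from compound 3 by 2-methylphenyl in place of naphthalen-2-yl on an oxygen on a saturated carbon, the same change as from compound 2 to compound 1, at the same place; the two cores differ by fluoro in place of chloro on an aromatic carbon. The step from compound 3 to compound 4 is expected to be about an at least 1.6-fold lower number from compound 3 to compound 4 (0.22 log units; that floor lies within the scatter), resting on the step from compound 2 to compound 1 a 4.5-fold lower number from compound 2 to compound 1 (0.66 log units; beyond the scatter), though the limit on compound 3 leaves the starting point uncertain. For compound 4 in this assay the estimate is 60 ug/mL, between 20 ug/mL and 150 ug/mL.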

Compound 4, half-maximal inhibitory concentration: > 100 ug/mL
Compound 4 was reported as a limit; the forecaster's own chance of this, stated with the estimate: 40%; at least 1.6-fold (0.22 log units) between middle value and limit.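

Compound 4 is reported only as a limit in this assay: the limit of > 100 ug/mL in this assay, at which 2 of the 4 values shown sit. Fluoro in place of chloro on an aromatic carbon gives an at least 4.5-fold higher number from compound 1 to compound 4 (0.65 log units; beyond the scatter), so on the core carrying 2-methylphenyl the halogen change does shift the read-out, and the lower number of compound 1 does not carry over to its fluoro counterpart as a measured value. The steps that end on a limit cannot be read, so this shows a loss on one core only and does not show whether the halogen change has the same size on both cores: the same change on two cores in this assay, a number no lower (the limit leaves the size open) from compound 2 to compound 3 and an at least 4.5-fold higher number (0.65 log units; beyond the scatter) from compound 1 to compound 4; the limit leaves it open whether they differ.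

From the compounds shown here alone, whether 2-methylphenyl offers anything over naphthalen-2-yl on the fluoro core stays open, since neither compound gives a number there. Also open, going by these compounds, is how the series reads with bromo or hydrogen in place of the halogen, or with an unsubstituted phenoxy group or an amine in place of the aryloxy group.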